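The source may report more compounds than this note shows. Statements on the series, on what has been measured and on what is new or still open speak of the compounds shown alone.

For the measured compounds named here, compound 1 `Cc1cc(-c2ccnc(Nc3ccc(N(C)C)cc3)n2)c(C)o1` is the only member of this set with a number: in a functional assay for inhibition, with Homo sapiens as the target (on this read-out higher numbers stand for weaker inhibition and lower numbers for stronger inhibition), compound 1 gives 4900 nM. Compound 2 `CCN(CC)c1ccc(Nc2nccc(-c3cc(C)oc3C)n2)cc1` differs from it by diethylamino in place of dimethylamino on an aromatic carbon. In this assay compound 2 gives > 24000 nM, which is a limit of the assay and not a number. Going by the values given here, the only measured step, an at least 4.8-fold higher number from compound 1 to compound 2 (0.69 log units; beyond the scatter), therefore rests on (the limit of > 24000 nM in this assay, at which 1 of the 2 values shown sits). Compound 3 `CN(C)c1ccc(Nc2nccc(-c3cccs3)n2)cc1` departs from compound 1 in a different place: thiophen-2-yl in place of 2,5-dimethylfuran-3-yl on an aromatic carbon. Among the compounds with values here, the measured step from compound 1 to compound 2 leaves this five-membered ring untouched, and no measured step bears on the change to compound 3; both the direction and the size of its effect in this assay remain open. With nothing in the data to set it apart from compound 1, compound 3 is expected to stay near the same level, a 1.0-fold higher number from compound 1 to compound 3 (0.01 log units; within the scatter) being no step beyond the scatter. Compound 3 is accordingly estimated at 5000 nM in this assay, within a deliberately wide range from 1500 nM to 20000 nM that carries this uncertainty.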

Compound 3, half-maximal inhibitory concentration: 900 nM
Estimate against measurement, compound 3: 5.6-fold (0.74 log units) above; the measured number lies below the stated range.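

In this assay, thiophen-2-yl in place of 2,5-dimethylfuran-3-yl gives a 5.4-fold lower number from compound 1 to compound 3 (0.74 log units; beyond the scatter) and so shows that the group on this aromatic carbon, next to the ring nitrogen, has a bearing on the read-out. The earlier step concerned only the dialkylamino group at the other end of the molecule, whereas this one shows that a change on the shared core can bring a lower number while dimethylamino stays in place. The exchange alters several things at once, since the oxygen gives way to sulfur, both methyl groups are lost and the ring is attached through a different carbon, and nothing shown here explains the drop or assigns it to any one of these differences.

The compounds shown leave open which of these differences carries the step, a question that furan-2-yl, thiophen-3-yl or 2,5-dimethylthiophen-3-yl at this position could help to separate. They also leave open whether a six-membered ring such as phenyl would serve here, and how diethylamino behaves when thiophen-2-yl is present.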